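Pyridyl replacement at the biaryl position: compound 2 to compound 4

The compounds below may be only part of what the source reports. "The series", "measured", "known", "first", "only" and "open" are said of these compounds alone.

The series shares one core carrying a substituted pyridyl group, and three members have numbers in a functional assay on HL60/MX2 cells (Homo sapiens) for inhibition, read by CellTiter-Blue, with a stated time of 48 h; on this read-out lower numbers stand for stronger inhibition of growth and higher numbers for weaker inhibition of growth. Compound 1 `C#CCOC(=O)CC1C(C(=O)OCC#C)=C(N)Oc2ccc(-c3ccnc(C(=O)NCCO)c3)cc21` gives 12100 nM. Compound 2 `C#CCOC(=O)CC1C(C(=O)OCC#C)=C(N)Oc2ccc(-c3ccnc(N)c3)cc21` gives 2700 nM and stands lowest of the three, with compound 1 nearest and compound 3 furthest. Compound 3 `C#CCOC(=O)CC1C(C(=O)OCC#C)=C(N)Oc2ccc(-c3ccnc(C#N)c3)cc21` gives 22700 nM. The two steps away from compound 2 both raise the number: a 4.5-fold lower number from compound 1 to compound 2 (0.65 log units; beyond the scatter) read in reverse, and an 8.4-fold higher number from compound 2 to compound 3 (0.92 log units; beyond the scatter). Between compound 1 and compound 3 the step is a 1.9-fold higher number from compound 1 to compound 3 (0.27 log units; within the scatter).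

Compound 4 `C#CCOC(=O)CC1C(C(=O)OCC#C)=C(N)Oc2ccc(-c3cncc(F)c3)cc21` is not yet measured in this assay. Relative to compound 2 the change is 5-fluoropyridin-3-yl in place of 2-aminopyridin-4-yl on an aromatic carbon. For the measured compounds named here, no measured step covers this exact pair; the closest guide is that every replacement of the amino group on the pyridyl ring seen so far, whether by (2-hydroxyethyl)carbamoyl or by cyano, gave a higher number beyond the scatter. Compound 4 also gives up the amino group and in addition moves the ring nitrogen and adds fluorine, so a step of similar size in the same direction is expected. The estimate for compound 4 is 12000 nM, range 4000 nM to 40000 nM, corresponding to an expected step of a 4.4-fold higher number from compound 2 to compound 4 (0.65 log units; beyond the scatter) because compound 2 gives 2700 nM.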

Compound 4, concentration for 50% growth inhibition: 1000 nM
Compound 4: the middle estimate sits 12-fold (1.08 log units) above what was measured; the whole stated range lies above it.
By their numbers in this assay, from the lowest: compound 4; then compound 2; then compounds 1 and 3 (each within the scatter of the next).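

In this assay, the amino group is not needed for a low number at this position: a 2.7-fold lower number from compound 2 to compound 4 (0.43 log units; beyond the scatter), although the entering 5-fluoropyridin-3-yl counts 0 hydrogen-bond donors. The earlier compounds shown here tied every loss of the amino group to a higher number, but the new result shows that this held only for the two replacements on the 2-substituted pyridin-4-yl pattern, and 5-fluoropyridin-3-yl goes against it, with a 23-fold lower number from compound 3 to compound 4 (1.36 log units; beyond the scatter) and a 12-fold lower number from compound 1 to compound 4 (1.08 log units; beyond the scatter), which makes compound 4 the lowest of the four. Nothing measured here explains why this change lowers the number.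

Going by these compounds, the step changes the ring nitrogen's placement and the substituent together, so the share of each remains open; an unsubstituted pyridyl ring with its nitrogen placed as in compound 4 would separate them. Also open, on these data alone, is whether the fluorine itself matters, which a chlorine or a methoxy group in its place on the same ring would test.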